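Methylpiperazinium for Piperidinium in Two Collagen Promoter Series

The compounds below may be only part of what the source reports. "The series", "measured", "known", "first", "only" and "open" are said of these compounds alone.

Compound 1 `CC[N+]1(CCCCCCCOc2ccc(-n3cc(C(=O)Nc4cc(F)cc(F)c4)c(=O)c4ccc(N(C)C)nc43)cc2C)CCCCC1`: 53.4%
Compound 2 `CC[N+]1(CCCCCCCOc2cc(C)cc(-n3cc(C(=O)Nc4cc(F)cc(F)c4)c(=O)c4ccc(N(C)C)nc43)c2)CCCCC1`: 86.6%
Compound 3 `Cc1cc(-n2cc(C(=O)Nc3cc(F)cc(F)c3)c(=O)c3ccc(N(C)C)nc32)ccc1OCCCCCCC[N+]1(C)CCN(C)CC1`: 32%

Three compounds were measured in an assay on LX2 cells for inhibition of COL1A1 promoter (Homo sapiens), read by a luciferase reporter, with a stated time of 24 h, tested at 50 uM; a lower number here means a weaker effect, a higher number a stronger effect of the compound at the concentration tested. Compound 1 gives 53.4% in this assay. Compound 2 gives 86.6%, the highest of the three, and compound 3 gives 32%. Compounds 1 and 2 are built from the same atoms joined differently; the difference between the two cores is not broken down here.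

Compounds 1 and 3 differ in one place: a group of 8 heavy atoms (6 carbon, 2 nitrogen; one six-membered non-aromatic ring with 2 hetero atoms) in place of a group of 8 heavy atoms (7 carbon, 1 nitrogen; one six-membered non-aromatic ring with 1 hetero atom), on a saturated chain carbon, seven bonds along the chain from an oxygen on an aromatic ring. This change lowers the read-out, a number 21.4 percentage points lower from compound 1 to compound 3 (beyond the scatter).

The unmeasured compound 4 `Cc1cc(OCCCCCCC[N+]2(C)CCN(C)CC2)cc(-n2cc(C(=O)Nc3cc(F)cc(F)c3)c(=O)c3ccc(N(C)C)nc32)c1` carries the same kind of change on the core of compound 2: a group of 8 heavy atoms (6 carbon, 2 nitrogen; one six-membered non-aromatic ring with 2 hetero atoms) in place of a group of 8 heavy atoms (7 carbon, 1 nitrogen; one six-membered non-aromatic ring with 1 hetero atom), on a saturated chain carbon, seven bonds along the chain from an oxygen on an aromatic ring. The place is described in the same words for both pairs, seven bonds along the chain from an oxygen on an aromatic ring, so the surroundings of the change are alike as far as the count goes.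

For the measured compounds named here, the expectation for compound 4 rests on the single measured instance of this change, from compound 1 to compound 3, where the step of a number 21.4 percentage points lower from compound 1 to compound 3 (beyond the scatter) lowered the read-out. Compound 4 is therefore expected to sit below compound 2 in this assay, by a step estimated as a number 21.6 percentage points lower from compound 2 to compound 4 (beyond the scatter). The estimate for compound 4 in this assay is 65%, with a range of 45% to 82%, which is expected to cover it.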

Compound 4, a percentage reported as inhibition, at one concentration (the size of the read-out at that concentration, not a potency): 38.2%
Estimate against measurement, compound 4: 26.8 percentage points above, and the stated range ends above it.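

On the core of compound 2, setting the six-membered non-aromatic ring with 2 hetero atoms in place of the one with 1 hetero atom, on the same saturated chain carbon, gives a result in this assay that is a number 48.4 percentage points lower from compound 2 to compound 4 (beyond the scatter). The change therefore lowers the read-out on both cores measured, but the size of the step does not carry over from one core to the other: the same change on two cores in this assay, a number 21.4 percentage points lower (beyond the scatter) from compound 1 to compound 3 and a number 48.4 percentage points lower (beyond the scatter) from compound 2 to compound 4, 27 percentage points apart, beyond the scatter of two such steps

For these two pairs, the direction of the change could be carried across, while its size could not be taken from one core and applied to the other; two pairs establish no rule for the series, and they do not show which difference between the cores goes with the larger step, nor whether the same would be seen at other concentrations, since each read-out comes from a single one.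

As far as these compounds go, it remains open whether a morpholinium or pyrrolidinium ring at the end of the chain would also give steps that differ between the two cores. A shorter or longer chain, or a tertiary amine in place of the charged nitrogen, could also alter the size of the step, and the compounds shown do not address this.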